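Swapping a thiadiazole for a tetrazole on a weakly cytotoxic hydrazide

A few compounds are considered here, and "the series" means these few. Any claim that something is new, unique, unknown or untested is made for them only; others in the source may bear on it.

Measured so far in a functional assay on C6 cells (Rattus norvegicus) for cytotoxicity, read by MTT assay, with a stated time of 24 h; a lower number here means a stronger inhibitor, a higher number a weaker inhibitor:
compound 1 `Cc1nnc(SCC(=O)N/N=c2/scc(-c3ccccc3)n2-c2ccccc2)s1`: > 200 ug/mL
compound 2 `Cc1nnc(SCC(=O)N/N=c2/scc(-c3ccc(C#N)cc3)n2-c2ccccc2)s1`: "not determined" (no result reported)
compound 3 `Cc1nnc(SCC(=O)N/N=c2/scc(-c3ccc(Br)cc3)n2-c2ccccc2)s1`: "not determined" (no result reported)

Compound 1 gives only a limit in this assay, > 200 ug/mL, meaning no half-maximal inhibitory concentration could be read within the tested range. For compound 2 the result is "not determined" (no result reported), and for compound 3 it is "not determined" (no result reported), so no number stands beside either of them. Going by the values given here, the only evidence on record is therefore (the limit of > 200 ug/mL in this assay, at which 1 of the 3 values shown sits), and nothing in the set allows a comparison between two measured values.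

Compound 4 `Cn1nnnc1SCC(=O)N/N=c1/scc(-c2ccccc2)n1-c1ccccc1` has not been measured. It differs from compound 1 in one place: 1-methyl-1H-tetrazol-5-yl in place of 5-methyl-1,3,4-thiadiazol-2-yl on a sulfur. Both groups are small, five-membered aromatic rings carrying a methyl, so the shared core and the rest of the molecule stay the same.

Among the compounds with values here, with compound 1 sitting at the limit and no measured step to lean on, no change beyond the usual scatter is expected from compound 1 to compound 4, and the expected step of a number no higher from compound 1 to compound 4 (the limit leaves the size open) is close to none. Compound 4 is estimated to give 200 ug/mL in this assay, within a range from 100 ug/mL to 400 ug/mL, most likely again reported only as a limit.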

Compound 4, half-maximal inhibitory concentration: 67.7 ug/mL
Beside the measured number, compound 4's estimate is 3.0-fold (0.47 log units) above it; measured number outside the range, below it.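

The ring on the sulfur turns out to matter in this assay, with an at least 2.9-fold lower number from compound 1 to compound 4 (0.47 log units; beyond the scatter) when 1-methyl-1H-tetrazol-5-yl replaces 5-methyl-1,3,4-thiadiazol-2-yl. Going by these compounds alone, the two groups match in heavy-atom count, are both five-membered aromatic rings, and both have no hydrogen-bond donors and no net charge, yet they differ in their ring atoms and hydrogen-bond acceptors; the data cannot say which of these differences counts, only that this one exchange, with the rest of the molecule unchanged, is enough to bring a half-maximal inhibitory concentration within the tested range. From the compounds shown here alone, the true size of the step remains unknown because one end of it is only a limit, not a number: the limit of > 200 ug/mL in this assay, at which 1 of the 4 values shown sits.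

Still open, going by these compounds, is how the number would respond to a different group on the same sulfur, such as a 1,2,4-triazole ring, a carboxylic acid on a short chain or an amine. It is also unclear whether the tetrazole would have a similar effect alongside the nitrile or the bromine on the phenyl ring, since the thiadiazole compounds carrying those groups offer no number for comparison.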